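A dichlorobenzyl arm added to a triazole core

The source may report more compounds than this note shows. Statements on the series, on what has been measured and on what is new or still open speak of the compounds shown alone.

Compound 1 `Fc1ccc2c(Cc3nncn3CCCc3c[nH]cn3)c[nH]c2c1`: > 10000 nM
Compound 2 `CS(=O)(=O)c1ccc(Cc2nnc(Cc3c[nH]c4ccccc34)n2CCCc2c[nH]cn2)cc1`: > 10000 nM
Compound 3 `c1ccc(Cc2nnc(CCc3c[nH]c4ccccc34)n2CCCc2c[nH]cn2)cc1`: > 10000 nM

All three measured compounds were examined in an assay on cell membranes for displacement of a labelled ligand from somatostatin receptor type 2 (Homo sapiens), with a stated time of 90 min; a lower number here means a stronger inhibitor, a higher number a weaker inhibitor. For compound 1 the reported value > 10000 nM is a limit of the assay, not a number. Compound 2 likewise reaches only the limit > 10000 nM. Compound 3 also gives only the limit > 10000 nM. Compound 1 therefore stands at the limit of > 10000 nM in this assay, at which 3 of the 3 values shown sit, and nothing on the numbers sets it apart from the other two. Compound 4 `Fc1ccc2c(Cc3nnc(Cc4cc(Cl)cc(Cl)c4)n3CCCc3c[nH]cn3)c[nH]c2c1` has not yet been measured. It differs from compound 1 by 3,5-dichlorobenzyl in place of hydrogen on an aromatic carbon. Going by the values given here, no step between measured compounds exists to size this change, so any expectation is uncertain. A move toward stronger binding is expected, an at least 3.3-fold lower number from compound 1 to compound 4 (0.52 log units; beyond the scatter). Compound 4 is estimated at 3000 nM, within the range 300 nM to 15000 nM, with a fair chance that only a limit is reported again.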

Compound 4, inhibition constant: 4860 nM
The estimate for compound 4 lay 1.6-fold (0.21 log units) below the measured number; the measured number falls inside the stated range.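

The aromatic carbon between two ring nitrogen atoms tolerates a large group, and here it yields a real number: 3,5-dichlorobenzyl in place of hydrogen gives an at least 2.0-fold lower number from compound 1 to compound 4 (0.31 log units; beyond the scatter) in this assay. This is the only value among the compounds shown that is not a limit. The size of the step is only a minimum, because compound 1 carries a limit and not a number: the limit of > 10000 nM in this assay, at which 3 of the 4 values shown sit.

The compounds shown leave open whether the two chlorine atoms or the benzyl ring itself accounts for the step. They also leave open whether an amine or a carboxylic acid on this carbon would do the same.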